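The compounds below may be only part of what the source reports. "The series", "measured", "known", "first", "only" and "open" are said of these compounds alone.

Measured so far:
- Compound 1 `CC(C)c1ccc(NC(=O)C2CCN(C/C=C/c3ccccc3)CC2)cc1`: 5200 nM
- Compound 2 `COc1cccc(NC(=O)C2CCN(C/C=C/c3ccccc3)CC2)c1`: 37200 nM
- Compound 3 `O=C(Nc1cccc(F)c1)C1CCN(C/C=C/c2ccccc2)CC1`: 23300 nM

In a functional assay on MGC-803 cells (Homo sapiens) for inhibition, read by MTT assay, with a stated time of 72 h (a lower number here means a stronger inhibitor, a higher number a weaker inhibitor), compound 1 stands lowest of the three at 5200 nM, and its steps to both others lie beyond the scatter. Compound 4 `CN1CCN(c2ccc(NC(=O)C3CCN(C/C=C/c4ccccc4)CC3)cc2)CC1` has not yet been measured. It differs from compound 1 by a single change: 4-methylpiperazin-1-yl in place of isopropyl on an aromatic carbon. In words, 4-methylpiperazin-1-yl takes the place of isopropyl on an aromatic carbon, para to a large group.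

Among the measured compounds shown here, no measured step makes this exact replacement. For the measured compounds named here, two steps bear on it indirectly, as each gives up the 4-isopropylphenyl group: a 7.2-fold higher number from compound 1 to compound 2 (0.85 log units; beyond the scatter) and a 4.5-fold higher number from compound 1 to compound 3 (0.65 log units; beyond the scatter). Both are modest. The remaining step, a 1.6-fold lower number from compound 2 to compound 3 (0.20 log units; within the scatter), lies within the scatter and adds little. Neither compound 2 nor compound 3 keeps a group where the isopropyl stood, whereas compound 4 does, so a modest rise in the number in this assay is expected, somewhat smaller than those two steps. The expected change is a 2.1-fold higher number from compound 1 to compound 4 (0.33 log units; beyond the scatter). Compound 4 is estimated at 11000 nM, with an expected range from 3000 nM to 35000 nM.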

Compound 4, half-maximal inhibitory concentration: 14000 nM
Estimate against measurement, compound 4: 1.3-fold (0.10 log units) below; the range from low to high includes it.
By their numbers in this assay, from the lowest: compound 1; then compounds 4, 3 and 2 (each within the scatter of the next, the first and the last beyond it).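

In this assay, among the compounds shown here, a 2.7-fold higher number from compound 1 to compound 4 (0.43 log units; beyond the scatter) is the first step to change only the group on the aromatic carbon para to a large group, leaving the rest of compound 1 in place. Isopropyl, with 3 heavy atoms and no ring, gives way to 4-methylpiperazin-1-yl, with 7 heavy atoms, a six-membered non-aromatic ring and 2 hydrogen-bond acceptors, yet the step remains modest, so this place admits a much larger group containing nitrogen at a moderate cost in this assay, and compound 1 remains the lowest of the four. Nothing measured here accounts for the size of this step.

The compounds shown do not separate the added ring from its nitrogens. A cyclohexyl ring, a morpholine ring or a dimethylamino group at this place would help to separate the two. As far as these compounds go, they also give no reference with plain hydrogen at this place, so it remains unknown whether isopropyl or 4-methylpiperazin-1-yl improves on the unsubstituted phenyl ring at all.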